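Working notes: the step from compound 3 to compound 4

A few compounds are considered here, and "the series" means these few. Any claim that something is new, unique, unknown or untested is made for them only; others in the source may bear on it.

Measured in a functional assay on HeLa cells (Homo sapiens) for inhibition, with a stated time of 72 h; on this read-out higher numbers stand for an effect only at larger amounts of compound and lower numbers for an effect already at smaller amounts:
- compound 1 `COc1cc(CNC2CCCCC2)ccc1OCc1ccc(Cl)nc1`: "nd(insoluble)" (no result reported)
- compound 2 `COc1cc(CNCc2ccncc2)ccc1OCc1ccccc1F`: 5100 nM
- compound 3 `COc1cc(CNCCCN(C)C)ccc1OCc1ccc(Cl)nc1`: 5000 nM

Compound 2 gives 5100 nM and compound 3 gives 5000 nM, two values within the scatter of each other. Compound 1 supplies no number for comparison, leaving compound 3 with a single numerical neighbour in this assay.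

Compound 4 `COCCNCc1ccc(OCc2ccc(Cl)nc2)c(OC)c1` has not yet been measured. It differs from compound 3 as follows: methoxy in place of (dimethylamino)methyl on a saturated chain carbon, two bonds along the chain from an amine nitrogen. In words, this is methoxy in place of (dimethylamino)methyl on a saturated chain carbon, two bonds along the chain from an amine nitrogen.

For the measured compounds named here, no measured pair differs in one place only, so no direct precedent exists for this change. The evidence is limited to the agreement between compound 2 at 5100 nM and compound 3 at 5000 nM. A slight move toward a higher number is expected, within the scatter: a 1.4-fold higher number from compound 3 to compound 4 (0.15 log units; within the scatter). The range is kept wide to reflect how little the series shows so far. For compound 4 the expected value in this assay is 7000 nM, with an estimated range of 2500 nM to 20000 nM.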

Compound 4, half-maximal effective concentration: 97000 nM
Compound 4: middle estimate off by 14-fold (1.14 log units), on the low side; measured number outside the range, above it.
By their numbers in this assay, from the lowest: compounds 3 and 2 (each within the scatter of the next); then compound 4.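

In this assay, the chain end on the amine of the shared core proves to be a position that the read-out responds to strongly: methoxy in place of (dimethylamino)methyl, on a saturated chain carbon, two bonds along the chain from an amine nitrogen, gives a 19-fold higher number from compound 3 to compound 4 (1.29 log units; beyond the scatter). For the compounds shown here, this is the first step that differs in one place, and the hydrogen-bond donor and acceptor counts of the leaving and entering groups are the same, so those counts do not follow the step, while the atoms and the size of the group do change. Nothing measured on these compounds accounts for the size of the step.

The single step joins two changes, the dimethylamino group giving way to methoxy and 3-(dimethylamino)propyl shortening to 2-methoxyethyl, and the compounds shown do not separate them. A 3-methoxypropyl chain would bear on the chain length alone, while a primary amine or a carboxylic acid at the chain end would show how specific the response is to the dimethylamino group.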